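A few compounds are considered here, and "the series" means these few. Any claim that something is new, unique, unknown or untested is made for them only; others in the source may bear on it.

Measured so far in an assay for binding affinity to dual specificity mitogen-activated protein kinase kinase 4 (Homo sapiens), read by KINOMEscan, tested at 100 nM; on this read-out lower numbers stand for a stronger effect and higher numbers for a weaker effect at the one concentration tested:

Compound 1 `CCCS(=O)(=O)Nc1ccc(F)c(C(=O)c2n[nH]c3ncc(-c4ccccc4)cc23)c1F` gives 2.4%.
Compound 2 `CCCS(=O)(=O)Nc1ccc(F)c(C(=O)c2n[nH]c3ncc(-c4ccccc4C)cc23)c1F` gives 7%.
Compound 3 `CCCS(=O)(=O)Nc1ccc(F)c(C(=O)c2n[nH]c3ncc(-c4ccc(N)cc4)cc23)c1F` gives 0.1%.

Compound 3 holds the lowest of the three numbers, yet its separations from the others, a number 2.3 percentage points lower from compound 1 to compound 3 (within the scatter) and a number 6.9 percentage points lower from compound 2 to compound 3 (within the scatter), both lie within the scatter, so the three compounds cannot be ranked. Compound 4 `CCCS(=O)(=O)Nc1ccc(F)c(C(=O)c2n[nH]c3ncc(-c4ccc(S(=O)(=O)NC)cc4)cc23)c1F` differs from compound 3 as follows: methylsulfamoyl in place of amino on an aromatic carbon. Among the measured compounds shown here, no measured step changes this group into methylsulfamoyl; the two steps altering the same aromatic carbon region, a number 4.6 percentage points higher from compound 1 to compound 2 (within the scatter) and a number 2.3 percentage points lower from compound 1 to compound 3 (within the scatter), were both within the scatter. A step of the size a number 1.9 percentage points higher from compound 3 to compound 4 (within the scatter) in this assay is therefore expected, one that stays within the scatter. Compound 4 is estimated at 2%, between 0.1% and 15%.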

Compound 4, a percentage reported as activity, at one concentration (the size of the read-out at that concentration, not a potency): 1.2%
Compound 4: the middle estimate sits 0.8 percentage points above what was measured; the range from low to high includes it.
By their numbers in this assay, from the lowest: compounds 3, 4, 1 and 2 (each within the scatter of the next).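

In this assay, putting methylsulfamoyl, with 5 heavy atoms, in place of the single heavy atom of amino on this aromatic carbon gives a number 1.1 percentage points higher from compound 3 to compound 4 (within the scatter). The other two comparisons, a number 1.2 percentage points lower from compound 1 to compound 4 (within the scatter) and a number 5.8 percentage points lower from compound 2 to compound 4 (within the scatter), also show no readable change, so even this much larger group leaves the number within the scatter of compounds 1, 2 and 3. Nothing available explains this tolerance.

On these data alone, whether a carboxylic acid or a morpholine here would move the number beyond the scatter remains open. A single concentration also leaves any potency differences among these compounds unresolved.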